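Nitrogen substituent exchange and tolerated concentration in the series

This account rests on a few compounds, and the source may have more. Where it says the series, first, only, none or still open, it means among the compounds named here.

Compound 1 `CCCCCn1cc(C(=O)O)c(=O)c2c(O)c(Cc3cccc(Cl)c3F)ccc21` stands highest of the three numbers in an ADME assay on C8166 cells (Homo sapiens) for cytotoxicity, read by MTT assay; a lower number here means that less compound is tolerated, a higher number that more compound is tolerated: compound 1 gives 39900 nM. Compound 2 `CC(C)n1cc(C(=O)O)c(=O)c2c(O)c(Cc3cccc(Cl)c3F)ccc21` gives 26500 nM, a change of a 1.5-fold lower number from compound 1 to compound 2 (0.18 log units; within the scatter). Compound 3 `CC(C)Cn1cc(C(=O)O)c(=O)c2c(O)c(Cc3cccc(Cl)c3F)ccc21` gives 19500 nM, a change of a 2.0-fold lower number from compound 1 to compound 3 (0.31 log units; beyond the scatter); between those two compounds lies a 1.4-fold lower number from compound 2 to compound 3 (0.13 log units; within the scatter). Compound 4 `O=C(O)c1cn(C2CCCC2)c2ccc(Cc3cccc(Cl)c3F)c(O)c2c1=O` differs from compound 1 by cyclopentyl in place of pentyl on an aromatic nitrogen. The two steps that bear on it, a 1.5-fold lower number from compound 1 to compound 2 (0.18 log units; within the scatter) and a 2.0-fold lower number from compound 1 to compound 3 (0.31 log units; beyond the scatter), both exchange one group on the aromatic nitrogen for another and give at most a modest lowering. The step is therefore expected to be small, a 1.4-fold lower number from compound 1 to compound 4 (0.15 log units; within the scatter), either downward or none beyond the scatter. Compound 4 is estimated at 28000 nM, with a range from 14000 nM to 56000 nM.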

Compound 4, half-maximal cytotoxic concentration: 12400 nM
Compound 4: the middle estimate sits 2.3-fold (0.35 log units) above what was measured; measured number outside the range, below it.
By their numbers in this assay, from the lowest: compounds 4, 3, 2 and 1 (each within the scatter of the next, the first and the last beyond it).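

On the aromatic nitrogen, closing the five carbons of pentyl into cyclopentyl gives the largest step yet seen in this assay (a 3.2-fold lower number from compound 1 to compound 4 (0.51 log units; beyond the scatter)). The ring also separates from isopropyl (a 2.1-fold lower number from compound 2 to compound 4 (0.33 log units; beyond the scatter)), but not from isobutyl (a 1.6-fold lower number from compound 3 to compound 4 (0.20 log units; within the scatter)). Nothing measured here accounts for these steps. As far as these compounds go, whether cyclopropyl or cyclohexyl on this nitrogen would fall in the same range remains open. So does the outcome for a phenyl group or a chain carrying a hydroxyl group at this position.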